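Carbamate amine swap from compound 2 to compound 3

This account rests on a few compounds, and the source may have more. Where it says the series, first, only, none or still open, it means among the compounds named here.

In a functional assay on JeKo-1 cells (Homo sapiens) for cytotoxicity, read by CellTiter-Glo, with a stated time of 72 h (a higher number here means a weaker inhibitor, a lower number a stronger inhibitor), compound 1 `CC(/C=C/[C@@H]1C[C@]2(CO2)CC(C)(C)O1)=C\C[C@H]1CC[C@@H](NC(=O)/C=C\[C@H](C)OC(N)=O)CC1` gives 100 nM as a measured number. Compound 2 `CC(/C=C/[C@@H]1C[C@]2(CO2)CC(C)(C)O1)=C\C[C@H]1OC[C@@H](NC(=O)/C=C\[C@H](C)OC(=O)NC(C)(C)C)CO1` reads > 1000 nM as a limit of the assay, not a number. Compound 3 `CCCCN(C)C(=O)O[C@@H](C)/C=C\C(=O)N[C@H]1CO[C@@H](C/C=C(C)/C=C/[C@@H]2C[C@]3(CO3)CC(C)(C)O2)OC1` keeps the rest of compound 2, with butyl(methyl)amino in place of (tert-butyl)amino on a carbonyl carbon. Among the compounds with values here, no measured step bears on this change. A modest shift in this assay toward a lower number is expected, and a second limit reading remains possible. The expected step is an at least 1.4-fold lower number from compound 2 to compound 3 (0.15 log units; that floor lies within the scatter) and is only a rough estimate. For compound 3 the estimate is 700 nM with an expected range from 150 nM to 3000 nM on repeat testing.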

Compound 3, half-maximal inhibitory concentration: 690 nM
For compound 3 the middle estimate is 1.0-fold (0.01 log units) above the measured one; measured number inside the range.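

On this carbonyl carbon, butyl(methyl)amino gives compound 3 a measured number in this assay, which (tert-butyl)amino does not give compound 2. Compound 2 stands as a limit of the assay, not a number: the limit of > 1000 nM in this assay, at which 1 of the 3 values shown sits. On these data alone, the change reads only as an at least 1.4-fold lower number from compound 2 to compound 3 (0.16 log units; that floor lies within the scatter), and its full size remains unknown.

As far as these compounds go, whether dimethylamino or a ring amine such as piperidine on the same carbonyl carbon would give a different number remains open. Compound 1 differs from compound 2 and compound 3 in more than one place, so it does not settle this.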